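A Methoxycarbonyl Added to the Acetyl of Compound 2

The source may hold more compounds than are shown below. What is called first, only, known or untested is meant among the compounds shown, and "the series" means these compounds.

compound 1 `CN(C)c1ccc(C2CC(c3ccc(-n4ccnc4)cc3)=NN2)cc1`: -20.9%
compound 2 `CC(=O)N1N=C(c2ccc(N3CCN(C)CC3)cc2)CC1c1ccc(N(C)C)cc1`: -0.8%

In a functional assay on HCC1806 cells (Homo sapiens) for inhibition, read by sulforhodamine B assay, tested at 10 uM (on this read-out higher numbers stand for more inhibition at the one concentration tested (going by the name of the read-out) and lower numbers for less inhibition), compound 1 gives -20.9%, while compound 2 gives -0.8%, the higher of the two numbers and a gap beyond the scatter. Compound 3 `COC(=O)CC(=O)N1N=C(c2ccc(N3CCN(C)CC3)cc2)CC1c1ccc(N(C)C)cc1` differs from compound 2 only by methoxycarbonyl in place of hydrogen on a saturated chain carbon bound to a carbonyl carbon. Within the data shown here, no step between measured compounds is known here, and compound 2 itself sits near zero at -0.8%, so the change is expected to move the read-out little, in no clear direction. Compound 3 is estimated at 2%, in the range -15% to 20%. The step of a number 2.8 percentage points higher from compound 2 to compound 3 (within the scatter) is expected to stay within the scatter.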

Compound 3, a percentage reported as inhibition, at one concentration (the size of the read-out at that concentration, not a potency): -8.3%
Compound 3: middle estimate off by 10.3 percentage points, on the high side; the measured number falls inside the stated range.
By their numbers in this assay, from the lowest: compound 1; then compounds 3 and 2 (each within the scatter of the next).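

In this assay, among these compounds, the step at this position reads a number 7.5 percentage points lower from compound 2 to compound 3 (within the scatter) and so gives the first measure of a change on the acetyl of compound 2. Adding methoxycarbonyl, with its 4 heavy atoms, on the saturated chain carbon bound to a carbonyl carbon leaves the two compounds indistinguishable in this read-out. No measurement on hand accounts for this result.

On these data alone, it remains open whether a carboxylic acid in place of the methyl ester, an amine on this chain or a longer chain would give a clearly different number.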